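Bromo for Chloro at the Bottom of the Series

This account rests on a few compounds, and the source may have more. Where it says the series, first, only, none or still open, it means among the compounds named here.

compound 1 `CCN1CCN(c2cc(C)c3cc(NC(=O)c4ccc(F)cc4)ccc3n2)CC1` 19800 nM
compound 2 `CCN1CCN(c2cc(C)c3cc(NC(=O)c4ccc(F)c(F)c4)ccc3n2)CC1` 1980 nM
compound 3 `CCN1CCN(c2cc(C)c3cc(NC(=O)c4ccccc4Cl)ccc3n2)CC1` > 50000 nM

In a functional assay on SK-BR-3 cells (Homo sapiens) for antiproliferative activity, read by MTT assay, with a stated time of 72 h (on this read-out higher numbers stand for weaker inhibition and lower numbers for stronger inhibition), compound 1 gives 19800 nM and compound 2 gives 1980 nM, so a 10-fold lower number from compound 1 to compound 2 (1.00 log units; beyond the scatter). Compound 3 sits at > 50000 nM in this assay, which is a limit of the assay and not a number, as noted in the limit of > 50000 nM in this assay, at which 1 of the 3 values shown sits. Thus an at least 2.5-fold higher number from compound 1 to compound 3 (0.40 log units; beyond the scatter), and an at least 25-fold higher number from compound 2 to compound 3 (1.40 log units; beyond the scatter), which places compound 3 at the weak end of the three measured compounds.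

Compound 4 `CCN1CCN(c2cc(C)c3cc(NC(=O)c4ccccc4Br)ccc3n2)CC1` differs from compound 3 in one place: bromo in place of chloro on an aromatic carbon. Among the compounds with values here, none of the measured steps exchanges one halogen for another on the same ring; the steps from compound 1 and compound 2 to compound 3 replace the whole aryl group, and the step from compound 1 to compound 2 adds a fluoro. So no step beyond the scatter is expected here, and compound 4 is expected to remain near or beyond the limit, a step that the limit leaves unreadable from compound 3 to compound 4. Compound 4 is estimated at 60000 nM in this assay, within 20000 nM to 150000 nM.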

Compound 4, half-maximal inhibitory concentration: 39200 nM
Estimate against measurement, compound 4: 1.5-fold (0.18 log units) above; the range from low to high includes it.
By their numbers in this assay, from the lowest: compound 2; then compounds 1 and 4 (each within the scatter of the next). At a limit, above all of these: compound 3.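

On the aromatic carbon ortho to a large group, bromo gives a measured number where chloro gave only a limit, and an at least 1.2-fold lower number from compound 3 to compound 4 (0.10 log units; that floor lies within the scatter), so the size of this exchange cannot be read. The entry for compound 3 in this assay remains a limit and not a number: the limit of > 50000 nM in this assay, at which 1 of the 4 values shown sits. With a readable value for the 2-bromophenyl group, the comparison with the other aryl groups can now be sized: a 2.0-fold higher number from compound 1 to compound 4 (0.30 log units; within the scatter), and a 20-fold higher number from compound 2 to compound 4 (1.30 log units; beyond the scatter), so this group stands level with 4-fluorophenyl and well short of 3,4-difluorophenyl.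

On these data alone, what a methoxy, a nitrile or an amine on this same carbon would do to the number remains open. So does the effect of bromo on the ring of compound 2, where the number is lowest.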